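The source may hold more compounds than are shown below. What is called first, only, known or untested is meant among the compounds shown, and "the series" means these compounds.

Compound 1 `O=C(Nc1ncc([N+](=O)[O-])s1)c1cc(Cl)ccc1O` and compound 2 `O=C(Nc1ncc([N+](=O)[O-])s1)c1ccc(-c2ccc(Cl)cc2)o1` share one core and were both tested in an ADME assay on HEK-293T cells (Homo sapiens) for cytotoxicity, read by MTT assay, tested at 25 uM; on this read-out lower numbers stand for a stronger effect and higher numbers for a weaker effect at the one concentration tested. In this assay compound 1 gives 100%, while compound 2 gives 75%. Of these two numbers compound 2 stands lowest, and its gap to compound 1 lies beyond the usual scatter. Compound 3 `Cc1ccc(-c2ccc(C(=O)Nc3ncc([N+](=O)[O-])s3)o2)cc1` is the next compound, differing from compound 2 in one place: methyl in place of chloro on an aromatic carbon. Among the compounds with values here, no measured pair shows this exact change, so only a step within the scatter is expected in this assay, estimated as a number 3 percentage points higher from compound 2 to compound 3 (within the scatter). Compound 3 is therefore expected to give about 78%, within a range from 60% to 95%.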

Compound 3, a percentage reported as activity, at one concentration (the size of the read-out at that concentration, not a potency): 94.1%
Compound 3: middle estimate off by 16.1 percentage points, on the low side; the measured number falls inside the stated range.
By their numbers in this assay, from the lowest: compound 2; then compounds 3 and 1 (each within the scatter of the next).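

In this assay the change from 4-chlorophenyl to 4-methylphenyl gives a number 19.1 percentage points higher from compound 2 to compound 3 (beyond the scatter) and so a weaker effect at the one concentration tested. This shows that the group para to a large group matters for this read-out, even when one heavy atom simply replaces another. Nothing measured here accounts for the difference between chloro and methyl at this place. Still open, on these data alone, is how an amine or a methoxy group at the same place would read, and whether the same change would give a similar step with other groups on the shared core.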